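The compounds below may be only part of what the source reports. "The series", "measured", "known", "first", "only" and "open" are said of these compounds alone.

Of the compounds shown here, three have been tested so far in a functional assay on HCT-116 cells (Homo sapiens) for inhibition, read by sulforhodamine B assay, with a stated time of 48 h, tested at 50 uM; on this read-out lower numbers stand for less inhibition of growth and higher numbers for more inhibition of growth at the one concentration tested. Compound 1 `COc1ccccc1/C=C/C(=O)/C=C/c1ccc(OCc2cn(CCCOc3cc(=O)oc4ccccc34)nn2)c(OC)c1` gives 53%, the highest of the three numbers. Compound 2 `COc1ccccc1/C=C/C(=O)/C=C/c1ccc(OCc2cn(CCCCCOc3cc(=O)oc4ccccc34)nn2)c(OC)c1` gives 33%, and compound 3 `COc1cc(/C=C/C(=O)/C=C/c2cccs2)ccc1OCc1cn(CCCCCOc2cc(=O)oc3ccccc23)nn1` gives 31%; both of these lie beyond the scatter under compound 1. Compound 4 `COc1ccc(/C=C/C(=O)/C=C/c2ccc(OCc3cn(CCCOc4cc(=O)oc5ccccc45)nn3)c(OC)c2)cc1OC` has not yet been measured. It differs from compound 1 in one place: 3,4-dimethoxyphenyl in place of 2-methoxyphenyl on a double-bonded chain carbon bound to a double-bonded chain carbon. Within the data shown here, only one measured step bears on this sort of change, an exchange of the group sitting on a double-bonded chain carbon bound to a double-bonded chain carbon: a number 2 percentage points lower from compound 2 to compound 3 (within the scatter), so that exchange stayed within the scatter. Nothing more about this position is known from the measured compounds. A step of about that size is therefore expected for compound 4, namely a number 3 percentage points lower from compound 1 to compound 4 (within the scatter), with no clear direction. Compound 4 is thus estimated to give 50% in this assay, within a range from 35% to 65%.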

Compound 4, percent growth inhibition at one concentration: 67%
Compound 4: the middle estimate sits 17 percentage points below what was measured, outside the stated range (above it).
By their numbers in this assay, from the lowest: compounds 3 and 2 (each within the scatter of the next); then compound 1; then compound 4.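

With 3,4-dimethoxyphenyl in place of 2-methoxyphenyl, this assay shows a number 14 percentage points higher from compound 1 to compound 4 (beyond the scatter) and so reveals that the group on this double-bonded chain carbon can move the number beyond the scatter. Among these compounds, the only earlier exchange here, thiophen-2-yl in place of 2-methoxyphenyl, gave a number 2 percentage points lower from compound 2 to compound 3 (within the scatter) on a different chain, so an unchanged number is not the rule at this position. No measurement shown here accounts for the rise.

The compounds shown leave open whether the same exchange would also raise the number on the chain carried by compound 2 and compound 3. They also leave open whether a single methoxy group on the ring would do the same as the two in compound 4, and how a hydroxyphenyl or aminophenyl group would compare.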